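The source may hold more compounds than are shown below. What is called first, only, known or untested is meant among the compounds shown, and "the series" means these compounds.

Compound 1 `CN1CCN(CCCCOc2c(O)cc3oc(-c4ccccc4)cc(=O)c3c2O)CC1` carries a hydroxy group on its core and was tested in a functional assay on A549 cells (Homo sapiens) for antiproliferative activity, read by MTT assay, with a stated time of 48 h; on this read-out lower numbers stand for stronger inhibition and higher numbers for weaker inhibition. In this assay compound 1 gives > 100000 nM, which is a limit of the assay rather than a measured number. Compound 1 thus sits at the limit of > 100000 nM in this assay, at which 1 of the 3 values shown sits, so no numerical potency can be attached to it. Two related compounds do give numbers: compound 2 `O=c1cc(-c2ccccc2)oc2cc(OCc3ccccc3)c(OCCCN3CCCC3)c(O)c12` gives 1400 nM, and compound 3 `COc1cc2oc(-c3ccccc3)cc(=O)c2c(O)c1OCCCN1CCN(C)CC1` gives 18000 nM. Compound 4 `CN1CCN(CCCCOc2c(OCc3ccccc3)cc3oc(-c4ccccc4)cc(=O)c3c2O)CC1` has not yet been measured. It differs from compound 1 in one place: benzyl in place of hydrogen on an oxygen on an aromatic ring. No pair of measured compounds differs in a single place, so this step has no direct precedent among the numbers shown. Compound 2, which also carries a benzyloxy group, gives 1400 nM. On that basis the change from hydroxy to benzyloxy is expected to strengthen inhibition well beyond the usual scatter, the expected step being an at least 20-fold lower number from compound 1 to compound 4 (1.30 log units; beyond the scatter). Compound 4 is therefore estimated at 5000 nM, with a likely range from 1500 nM to 20000 nM.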

Compound 4, half-maximal inhibitory concentration: 4400 nM
Compound 4: middle estimate off by 1.1-fold (0.06 log units), on the high side; the range from low to high includes it.
By their numbers in this assay, from the lowest: compound 2; then compound 4; then compound 3. At a limit, above all of these: compound 1.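

In this assay, within the data shown here, benzyl on this oxygen gives an at least 22-fold lower number from compound 1 to compound 4 (1.35 log units; beyond the scatter), the first direct evidence that the group on this oxygen strongly affects the read-out. From the compounds shown here alone, the true size of that step remains unknown, since compound 1 stands at a limit and not at a measured number: the limit of > 100000 nM in this assay, at which 1 of the 4 values shown sits. With the benzyloxy group shared, the amine end of the chain also matters: (4-methylpiperazin-1-yl)methyl in place of pyrrolidin-1-yl gives a 3.1-fold higher number from compound 2 to compound 4 (0.50 log units; beyond the scatter), a modest step beside the large benzyl one.

Going by these compounds, it remains open whether the aromatic ring of benzyl is needed, which a cyclohexylmethyl group on this oxygen, with a saturated ring instead, could test. How a morpholine at the end of the chain would compare with the two amines shown is also open.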